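Coumarin-bearing pyrazoline: aminomethyl carbonyl in place of aryl carbonyl

The source may report more compounds than this note shows. Statements on the series, on what has been measured and on what is new or still open speak of the compounds shown alone.

Measured so far:
compound 1, `CC1=NN(C(=O)CN2CCCC2)C(c2ccccc2O)C1`, 17900 nM
compound 2, `CC(=O)Oc1ccccc1C1CC(C)=NN1C(=O)CN1CCCCC1`, 4890 nM
compound 3, `Cc1ccc(C(=O)N2N=C(c3cc4ccccc4oc3=O)CC2c2ccccc2)cc1`, 31300 nM

In a functional assay on MGC-803 cells (Homo sapiens) for cytotoxicity, read by MTT assay, with a stated time of 48 h (on this read-out higher numbers stand for weaker inhibition and lower numbers for stronger inhibition), compound 3 gives 31300 nM, the highest of the three numbers. Its gap to compound 1 lies within the scatter, so the two cannot be told apart, whereas its gap to compound 2 lies beyond the scatter, and compound 2 gives the lowest number shown.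

Compound 4, `CC(C)CNCC(=O)N1N=C(c2cc3ccccc3oc2=O)CC1c1ccccc1`, differs from compound 3 at one place: (isobutylamino)methyl in place of 4-methylphenyl on a carbonyl carbon. This brings the carbonyl substituent closer in kind to those of compound 1 and compound 2, which both carry an aminomethyl group on the carbonyl carbon and give the two lower numbers in this assay. For the measured compounds named here, no step between measured compounds directly reports this change, so any expectation rests on that resemblance alone.

The step from compound 3 to compound 4 is expected to lower the number by a modest amount, a 2.6-fold lower number from compound 3 to compound 4 (0.42 log units; beyond the scatter), possibly no further than the scatter. Compound 4 is therefore estimated to give 12000 nM in this assay, with a range from 4000 nM to 40000 nM.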

Compound 4, half-maximal inhibitory concentration: 29700 nM
Compound 4: the middle estimate sits 2.5-fold (0.39 log units) below what was measured; the range from low to high includes it.
By their numbers in this assay, from the lowest: compound 2; then compounds 1, 4 and 3 (each within the scatter of the next).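

In this assay, this position now has its first direct reading (a 1.1-fold lower number from compound 3 to compound 4 (0.02 log units; within the scatter)), and on the shared core 4-methylphenyl and (isobutylamino)methyl on the carbonyl carbon cannot be told apart. For the compounds shown here, the resemblance to compound 1 and compound 2 therefore gains no support from this step: both differ from compound 4 in more than one place, so their numbers cannot be credited to an aminomethyl group on the carbonyl carbon. Nothing measured here explains why the exchange leaves the number within the scatter.

The compounds shown leave open whether any other group at this place would move the number on this core, such as a morpholine ring, an unsubstituted amine or a carboxylic acid. They also leave open whether a longer chain on the amine nitrogen would do so.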